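A ketone in place of the ester on the shared core

The source may hold more compounds than are shown below. What is called first, only, known or untested is meant among the compounds shown, and "the series" means these compounds.

Compound 1 has the structure `CC1=C(C(=O)OC(C)(C)C)C(c2ccoc2)NC(=O)N1`. In an assay on membranes from CHO cells for displacement of a labelled ligand from adenosine receptor A1 (Homo sapiens), read by scintillation counting, with a stated time of 60 min, tested at 1 uM (on this read-out higher numbers stand for more inhibition at the one concentration tested (going by the name of the read-out) and lower numbers for less inhibition), compound 1 gives 11%, which is the lower of the two numbers recorded here. Its measured companion is compound 2, with the structure `CC1=C(C(=O)OCc2ccccc2)C(c2ccoc2)NC(=O)N1`, and in this assay compound 2 gives 41%. Within the data shown here, the one step recorded between them is a number 30 percentage points higher from compound 1 to compound 2 (beyond the scatter).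

The compound not yet measured is compound 3, with the structure `CCCC(=O)C1=C(C)NC(=O)NC1c1ccoc1`. Its change from compound 1 is propyl in place of tert-butoxy on a carbonyl carbon. Among the measured compounds shown here, no recorded step covers this kind of change: the only step recorded exchanges one group for another on the oxygen of the ester, while here the oxygen of the ester itself leaves and a plain chain takes its place on the carbonyl carbon. That step is therefore only a loose guide, and it shows that changes at this part of the core can move the read-out modestly. With nothing closer to lean on, the expectation is a step of a number 4 percentage points higher from compound 1 to compound 3 (within the scatter), which is no change beyond the scatter. Compound 3 is therefore estimated at 15%, within a range from 0% to 40%.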

Compound 3, a percentage reported as inhibition, at one concentration (the size of the read-out at that concentration, not a potency): 1%
Beside the measured number, compound 3's estimate is 14 percentage points above it; measured number inside the range.
By their numbers in this assay, from the lowest: compounds 3 and 1 (each within the scatter of the next); then compound 2.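

Replacing tert-butoxy with propyl on the carbonyl carbon turns the ester into a ketone, and in this assay this gives a number 10 percentage points lower from compound 1 to compound 3 (within the scatter) and so leaves the two compounds indistinguishable. The ester oxygen can therefore leave the shared core, together with the tert-butyl group it carries, with no change that this read-out can resolve, something the earlier step could not show because it only exchanged the group on that oxygen. Compound 1 gives only 11% at the outset, however, so the read-out has little room to show a loss, and no measurement available here offers an explanation for the result.

Still open, going by these compounds, is whether a ketone can reach the level of compound 2, which gives 41% in this assay, and a ketone with benzyl on the carbonyl carbon would be the direct one-place comparison with compound 3. Also open, on these data alone, is how an amine on that carbonyl carbon, or a longer chain such as hexyl, would compare with propyl.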